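Swapping Fluoro for Methoxy on the Benzyl Group

A few compounds are considered here, and "the series" means these few. Any claim that something is new, unique, unknown or untested is made for them only; others in the source may bear on it.

Compound 1, `CCN1CCN(c2nc(NCc3ccc(F)cc3)nc3c2ncn3CCCN2CCCC2)CC1`: 40 nM
Compound 2, `CCN1CCN(CCCn2cnc3c(N4CCN(C5CCCC5)CC4)nc(N)nc32)CC1`: 280 nM
Compound 3, `CCN1CCN(CCCn2cnc3c(N4CCN(CC)CC4)nc(NCc4ccc(F)cc4)nc32)CC1`: 470 nM

In an assay on HEK293 cells for antagonist activity at Toll-like receptor 9 (Homo sapiens), read by spectrophotometry (on this read-out higher numbers stand for weaker inhibition and lower numbers for stronger inhibition), compound 1 gives the lowest number of the three, with compound 2 next and compound 3 furthest away. Compound 4, `CCN1CCN(c2nc(NCc3ccc(OC)cc3)nc3c2ncn3CCCN2CCCC2)CC1`, differs from compound 1 by methoxy in place of fluoro on an aromatic carbon. For the measured compounds named here, the only measured single-site step, a 12-fold higher number from compound 1 to compound 3 (1.07 log units; beyond the scatter), alters a different part of the molecule, so it says nothing direct about this swap. Going by the values given here, with no measured step that bears on the change, the expectation is a difference no larger than the usual scatter, in either direction. Compound 4 is therefore estimated at 45 nM, with an expected range of 15 nM to 140 nM, which means an expected step of a 1.1-fold higher number from compound 1 to compound 4 (0.05 log units; within the scatter).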

Compound 4, half-maximal inhibitory concentration in the Toll-like receptor 9 assay: 80 nM
Compound 4: middle estimate off by 1.8-fold (0.25 log units), on the low side; measured number inside the range.
By their numbers in the Toll-like receptor 9 assay, from the lowest: compounds 1 and 4 (each within the scatter of the next); then compounds 2 and 3 (each within the scatter of the next).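

In the Toll-like receptor 9 assay, methoxy in place of fluoro gives a 2.0-fold higher number from compound 1 to compound 4 (0.30 log units; within the scatter), so this first look at the benzyl group shows that the swap leaves the two compounds indistinguishable in inhibition. The same swap does separate them in a physicochemical assay for solubility, with a stated time of 18 h, at pH 7.4 (on this read-out higher numbers stand for higher solubility and lower numbers for lower solubility), where compound 1 gives 218 ug/mL and compound 4 gives 49.4 ug/mL as solubility drops: the measured solubility of compound 1, 218 ug/mL, and of compound 4, 49.4 ug/mL, a 4.4-fold lower number (0.64 log units; beyond the scatter)

Going by these compounds, this rests on a single pair, so it remains open whether the solubility drop is specific to methoxy. A hydroxyl, an amine or an ethoxy group at this position could behave differently in both read-outs.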